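A bare ring carbon gains an amino group

This account rests on a few compounds, and the source may have more. Where it says the series, first, only, none or still open, it means among the compounds named here.

Compound 1, `ClCc1ccccc1Cn1cnc2c(Cl)nc(Cl)nc21`: 5920 nM in a functional assay on UO-31 cells (Homo sapiens) for cytotoxicity, read by sulforhodamine B assay, with a stated time of 48 h; a higher number here means that more compound is tolerated, a lower number that less compound is tolerated
Compound 2, `ClCc1ccccc1Cn1cnc2c(Cl)ncnc21`: 61700 nM in this assay
Compound 3, `ClCc1cccc(Cn2cnc3nc(Cl)nc(Cl)c32)c1`: 72400 nM in this assay

Of the compounds shown here, three have been measured so far. Compound 2 gives the second highest of these three numbers; its nearest neighbour is compound 3, whose value lies within the usual scatter of that of compound 2, while compound 1 lies furthest away, beyond the scatter. Among the compounds with values here, only one traced single change joins two measured compounds: a 10-fold higher number from compound 1 to compound 2 (1.02 log units; beyond the scatter), a large step.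

Compound 4, `Nc1nc(Cl)c2ncn(Cc3ccccc3CCl)c2n1`, has not yet been measured. It differs from compound 2 by amino in place of hydrogen on an aromatic carbon, on an aromatic carbon of a six-membered aromatic ring with 2 nitrogen, between two ring nitrogen atoms, meta to a chloro group. Within the data shown here, the one measured step concerns a chloro leaving the shared core, not an amino entering it, so it bears only loosely on this change, and nothing measured tells the direction. The step expected here is a 1.2-fold lower number from compound 2 to compound 4 (0.09 log units; within the scatter), with little to anchor it. Compound 4 is expected to give about 50000 nM, in a range from 12000 nM to 150000 nM.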

Compound 4, concentration lethal to 50% of the cells: > 100000 nM
Compound 4: only a limit was reported; the forecaster's own chance of this, stated with the estimate: 10%; at least 2.0-fold (0.30 log units) between middle value and limit.
By their numbers in this assay, from the lowest: compound 1; then compounds 2 and 3 (each within the scatter of the next). At a limit, above all of these: compound 4.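

The chloro group of compound 1 now has two replacements on this ring carbon, which lies between two ring nitrogen atoms. With an at least 16-fold higher number from compound 1 to compound 4 (1.22 log units; beyond the scatter), amino joins hydrogen in giving a large rise in the number in this assay, so in these three compounds it is the chloro that stands apart. Between the two replacements, an at least 1.6-fold higher number from compound 2 to compound 4 (0.20 log units; that floor lies within the scatter) is a step whose floor lies within the scatter, so amino and hydrogen cannot yet be told apart here. Compound 4 gave only a limit: the limit of > 100000 nM in this assay, at which 1 of the 4 values shown sits.

As far as these compounds go, how far compound 4 lies past its limit stays unknown, and so does any true gap between amino and hydrogen. Also open, from the compounds shown here alone, is how a methoxy group, a methylamino group or a longer amine on this carbon would compare.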